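The source may report more compounds than this note shows. Statements on the series, on what has been measured and on what is new or still open speak of the compounds shown alone.

Compound 2 `CCC(=O)N1CCc2nc(C#Cc3ccccc3)sc2C1` holds the lowest number of the two measured in an assay on HEK293 cells for negative allosteric modulation of metabotropic glutamate receptor 5 (Homo sapiens), read by FLIPR, with a stated time of 1 h (a lower number here means a stronger inhibitor, a higher number a weaker inhibitor), where compound 2 gives 38 nM; compound 1 `CC(=O)N1CCc2nc(C#Cc3ccccc3)sc2C1` gives 90 nM. Compound 3 `O=C(C1CCCO1)N1CCc2nc(C#Cc3ccccc3)sc2C1` differs from compound 2 by oxolan-2-yl in place of ethyl on a carbonyl carbon. Among the measured compounds shown here, the only step that bears on this change in the acyl group is a 2.4-fold lower number from compound 1 to compound 2 (0.37 log units; beyond the scatter), which enlarged that group with a modest gain. A larger, ring-containing acyl group may not follow that trend, so compound 3 is expected to show about a 1.1-fold higher number from compound 2 to compound 3 (0.02 log units; within the scatter) in this assay. Compound 3 is therefore estimated at 40 nM, within a range of 12 nM to 130 nM.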

Compound 3, half-maximal inhibitory concentration: > 10000 nM
Compound 3 was reported as a limit (the forecaster's own chance of this, stated with the estimate: 3%); middle value at least 250-fold (2.39 log units) from the limit.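

Compound 3 is reported only as a limit, not as a number: the limit of > 10000 nM in this assay, at which 1 of the 3 values shown sits. Even so, the position on the carbonyl carbon proves far less forgiving than the modest gain from methyl to ethyl suggested: oxolan-2-yl in place of ethyl gives an at least 260-fold higher number from compound 2 to compound 3 (2.42 log units; beyond the scatter), and oxolan-2-yl in place of methyl gives an at least 110-fold higher number from compound 1 to compound 3 (2.04 log units; beyond the scatter). Enlarging this acyl group therefore does not simply continue the earlier trend. The compounds shown leave open whether the loss goes with the ring itself or with its oxygen, which a cyclopentyl group would separate, and whether a longer chain such as butanoyl keeps the gain seen with propanoyl.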